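This account rests on a few compounds, and the source may have more. Where it says the series, first, only, none or still open, it means among the compounds named here.

Measured so far in a functional assay on HepG2 cells (Homo sapiens) for inhibition, read by scintillation counting, with a stated time of 2 h; on this read-out higher numbers stand for weaker inhibition and lower numbers for stronger inhibition:
- compound 1 (`CCNC(=O)Nc1sc2ccccc2c1C(=O)N1CCN(C2CCN(C(=O)C3CCN(C(C)=O)CC3)CC2)CC1`): "not determined" (no result reported)
- compound 2 (`CCNC(=O)Nc1sc2ccccc2c1C(=O)N1CCN(C2CCN(C(=O)C3CCCC3)CC2)CC1`): 309 nM

Within the data shown here, compound 2 stands at 309 nM as the only number so far, and compound 1 offers no value for comparison. Compound 3 (`CCNC(=O)Nc1sc2ccccc2c1C(=O)N1CCN(C2CCN(C(=O)OC(C)C)CC2)CC1`) keeps the shared core but has isopropoxy in place of cyclopentyl on a carbonyl carbon. Among the measured compounds shown here, no measured pair shows the effect of such a change, so no step beyond the usual scatter, in either direction, is expected in this assay for it. The expected change is a 1.1-fold lower number from compound 2 to compound 3 (0.06 log units; within the scatter) as estimated. Compound 3 is estimated at 270 nM (expected range 80 nM to 900 nM).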

Compound 3, half-maximal inhibitory concentration: 208 nM
Compound 3: middle estimate off by 1.3-fold (0.11 log units), on the high side, and the stated range covers the measured number.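

On this carbonyl carbon, the cyclopentyl ring can give way to the open-chain, oxygen-linked isopropoxy with only a 1.5-fold lower number from compound 2 to compound 3 (0.17 log units; within the scatter) in this assay. This first measured pair therefore shows that turning cyclopentylcarbonyl into isopropoxycarbonyl leaves the number within the scatter, despite the loss of the ring and the gain of a hydrogen-bond acceptor. No supporting data bear on why this is so. On these data alone, whether an amine or a longer alkoxy chain on the same carbonyl carbon would move the number beyond the scatter remains open.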